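Morpholinyl for thiomorpholinyl in a small cytotoxicity series

A few compounds are considered here, and "the series" means these few. Any claim that something is new, unique, unknown or untested is made for them only; others in the source may bear on it.

Three compounds are measured and one is open. Compound 1 `Cc1ccnc(/C(N)=N/NC(=S)N2CCOCC2)c1` and compound 2 `Cc1ccnc(/C(N)=N/NC(=S)N2CCSCC2)c1` share one core; compound 3 `N/C(=N\NC(=S)N1CCSCC1)c1ccc(F)cn1` and compound 4 `N/C(=N\NC(=S)N1CCOCC1)c1ccc(F)cn1` share another. The difference between the two cores is not broken down here.

In a functional assay on HeLa cells (Homo sapiens) for cytotoxicity, read by MTT assay, with a stated time of 72 h, tested at 100 uM (a lower number here means less inhibition of growth, a higher number more inhibition of growth at the concentration tested), compound 2 gives 91.6%. In this assay compound 1 gives 82.7%. The change that separates them is morpholin-4-yl in place of thiomorpholin-4-yl on a thiocarbonyl carbon, and the step it made is a number 8.9 percentage points lower from compound 2 to compound 1 (within the scatter). In this assay compound 3 gives 88.1%; this number stands within the scatter of compound 2 and within the scatter of compound 1, so no order among the three can be read from it.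

Compound 4 carries the same change on the core of compound 3: morpholin-4-yl in place of thiomorpholin-4-yl on a thiocarbonyl carbon. The place is the same in both pairs, a thiocarbonyl carbon whose other neighbour is an amide-type nitrogen, so the two changes are the same change. A step of about the same size is expected from compound 3 to compound 4, because a number 8.9 percentage points lower from compound 2 to compound 1 (within the scatter) was the outcome of this change in the measured pair. The step that the estimate means is a number 9.1 percentage points lower from compound 3 to compound 4 (within the scatter), and it is expected to stay within the scatter. For compound 4 the expected value in this assay is 79%, with a range from 66% to 91%.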

Compound 4, percent growth inhibition at one concentration: 81.2%
The estimate for compound 4 lay 2.2 percentage points below the measured number; low and high end bracket the measured number.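

In this assay, the exchange of thiomorpholin-4-yl for morpholin-4-yl on the second core gives a number 6.9 percentage points lower from compound 3 to compound 4 (within the scatter). Set beside the same exchange on the first core, the two steps do not differ: the same change on two cores in this assay, a number 8.9 percentage points lower (within the scatter) from compound 2 to compound 1 and a number 6.9 percentage points lower (within the scatter) from compound 3 to compound 4, 2 percentage points apart, within the scatter of two such steps. Among the compounds shown here, this agreement shows only that the two pairs give no sign of a dependence on the core, so the earlier step was a fair guide to the later one; it does not show that the exchange has a real effect on growth inhibition, since each step taken alone remains within the scatter, and two cores cannot establish a rule for the whole series.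

The compounds shown leave open how other groups would read on the same thiocarbonyl carbon, such as a piperidine ring, a piperazine ring or an open-chain dimethylamine, and whether any of them would move the number beyond the scatter. They also leave open whether the close agreement between the two pairs would hold at concentrations lower than the single one tested, where growth inhibition would not lie so near the top of the scale.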